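The source may report more compounds than this note shows. Statements on the series, on what has been measured and on what is new or still open speak of the compounds shown alone.

Compound 2 `Fc1ccc(Oc2ccc3c(NCCCNCc4ccco4)ccnc3c2)cc1` gives 317 10^-6 cm/s in an ADME assay for permeability, using PAMPA, with a stated time of 30 min, at pH 7.4 (on this read-out higher numbers stand for higher permeability and lower numbers for lower permeability), level with compound 1 `CC(C)(C)c1ccc(Oc2ccc3c(NCCCNCc4ccco4)ccnc3c2)cc1` at 317 10^-6 cm/s and with compound 3 `COc1cccc(CNCCCNc2ccnc3cc(Oc4ccc(F)cc4)ccc23)c1O` at 317 10^-6 cm/s. Both measured steps, no change at the digits printed from compound 1 to compound 2 (within the scatter) and no change at the digits printed from compound 2 to compound 3 (within the scatter), stayed within the scatter. Compound 4 `c1coc(CNCCCNc2ccnc3cc(CC4CCCCC4)ccc23)c1` differs from compound 2 by cyclohexylmethyl in place of 4-fluorophenoxy on an aromatic carbon. Neither measured step alters this part of the core, so their bearing is indirect; still, nothing in the series has moved this assay beyond the scatter across changes of comparable scope. Compound 4 is therefore expected to show no step beyond the scatter, a 1.1-fold lower number from compound 2 to compound 4 (0.02 log units; within the scatter). The estimate for compound 4 in this assay is 300 10^-6 cm/s, with a range from 150 10^-6 cm/s to 450 10^-6 cm/s.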

Compound 4, apparent permeability: 23 10^-6 cm/s
Compound 4: middle estimate off by 13-fold (1.12 log units), on the high side; the whole stated range lies above it.
By their numbers in this assay, from the lowest: compound 4; then compounds 1, 2 and 3 (each within the scatter of the next).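

In this assay, among the compounds shown here, this aromatic carbon is the first place where a change goes beyond the scatter: cyclohexylmethyl in place of 4-fluorophenoxy gives a 14-fold lower number from compound 2 to compound 4 (1.14 log units; beyond the scatter), whereas the two earlier steps, both made elsewhere on the molecule, did not. No measurement shown accounts for this result. The change replaces the aromatic ring with a non-aromatic one and also alters its link to the core, so the compounds shown leave open which of the two matters. Benzyl or cyclohexyloxy on this carbon would separate them.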